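Removing a chloro group from a dithiocarbamate series

A few compounds are considered here, and "the series" means these few. Any claim that something is new, unique, unknown or untested is made for them only; others in the source may bear on it.

Three compounds share one core and differ only in the group on the thiocarbonyl carbon: compound 1 `CC1CCN(C(=S)SCc2ccc(C(=O)Nc3ccccc3N)cc2)CC1`, compound 2 `CN(Cc1ccncc1)C(=S)SCc1ccc(C(=O)Nc2ccccc2N)cc1` and compound 3 `Nc1ccccc1NC(=O)c1ccc(CSC(=S)N2CCc3cc(Cl)ccc32)cc1`. In a functional assay on A-375 cells (Homo sapiens) for antiproliferative activity, read by CCK-8 assay, with a stated time of 72 h, tested at 2 uM (on this read-out lower numbers stand for a weaker effect and higher numbers for a stronger effect at the one concentration tested), compound 1 gives 32.7%, compound 2 gives 31.4% and compound 3 gives 31.9%. Compound 3 stands second highest of the three, though its gaps to both neighbours are within the scatter. The steps of a number 1.3 percentage points lower from compound 1 to compound 2 (within the scatter), a number 0.8 percentage points lower from compound 1 to compound 3 (within the scatter) and a number 0.5 percentage points higher from compound 2 to compound 3 (within the scatter) all stay within the scatter. Compound 4 `Nc1ccccc1NC(=O)c1ccc(CSC(=S)N2CCc3ccccc32)cc1` differs from compound 3 by hydrogen in place of chloro on an aromatic carbon. Within the data shown here, no measured step removes this chloro, so the three exchanges at the thiocarbonyl carbon are the only guide, and they moved nothing beyond the scatter. Compound 4 is therefore expected to show no step beyond the scatter, an estimated a number 0.9 percentage points lower from compound 3 to compound 4 (within the scatter). The value of compound 4 in this assay is estimated at 31%, within 21% to 41%.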

Compound 4, a percentage reported as inhibition, at one concentration (the size of the read-out at that concentration, not a potency): 25.7%
Estimate against measurement, compound 4: 5.3 percentage points above, and the stated range covers the measured number.
By their numbers in this assay, from the lowest: compounds 4, 2, 3 and 1 (each within the scatter of the next).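

In this assay, the chloro on this aromatic carbon can be replaced by hydrogen without a step beyond the scatter (a number 6.2 percentage points lower from compound 3 to compound 4 (within the scatter)). The 2,3-dihydro-1H-indol-1-yl group also stays within the scatter of the two other groups on the thiocarbonyl carbon (a number 5.7 percentage points lower from compound 2 to compound 4 (within the scatter); a number 7 percentage points lower from compound 1 to compound 4 (within the scatter)). No evidence here bears on these numbers. From the compounds shown here alone, whether a methoxy, a methyl or a bromo group at this carbon would stay within the scatter remains open. So does whether this exchange behaves alike at other concentrations.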